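Propylamino replaces piperidin-1-yl on a thiocarbonyl carbon

The source may hold more compounds than are shown below. What is called first, only, known or untested is meant among the compounds shown, and "the series" means these compounds.

Compound 1 `Oc1ccc(C2C/C(=N\NC(=S)N3CCOCC3)c3ccc(O)cc3O2)cc1`: 76300 nM
Compound 2 `Oc1ccc(C2C/C(=N\NC(=S)N3CCCC3)c3ccc(O)cc3O2)cc1`: 65200 nM
Compound 3 `Oc1ccc(C2C/C(=N\NC(=S)N3CCCCC3)c3ccc(O)cc3O2)cc1`: 74400 nM

In a functional assay on HeLa cells (Homo sapiens) for cytotoxicity, read by MTT assay, with a stated time of 72 h (on this read-out lower numbers stand for stronger inhibition and higher numbers for weaker inhibition), compound 3 gives 74400 nM, and the measurements cannot separate it from the other two compounds. All three share one core and differ only in the ring attached to the thiocarbonyl carbon.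

The next compound, compound 4 `CCCNC(=S)N/N=C1\CC(c2ccc(O)cc2)Oc2cc(O)ccc21`, keeps that core but changes the group: propylamino in place of piperidin-1-yl on a thiocarbonyl carbon. In words, propylamino takes the place of piperidin-1-yl on a thiocarbonyl carbon.

Within the data shown here, three measured steps bear on this change. Exchanging morpholin-4-yl, pyrrolidin-1-yl and piperidin-1-yl for one another gave a 1.2-fold lower number from compound 1 to compound 2 (0.07 log units; within the scatter), a 1.0-fold lower number from compound 1 to compound 3 (0.01 log units; within the scatter) and a 1.1-fold higher number from compound 2 to compound 3 (0.06 log units; within the scatter). Each of these steps is small, but each only exchanges one ring for another. None shows what happens when a ring gives way to an open chain, so this evidence is indirect.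

No step beyond the scatter is therefore expected in this assay, in either direction, although the uncertainty is wider than for a ring exchange. The expected step is a 1.1-fold lower number from compound 3 to compound 4 (0.06 log units; within the scatter). For compound 4 the estimated value is 65000 nM, with an expected range of 30000 nM to 130000 nM.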

Compound 4, half-maximal inhibitory concentration: 40200 nM
Compound 4: middle estimate off by 1.6-fold (0.21 log units), on the high side, within the range that was stated.
By their numbers in this assay, from the lowest: compounds 4, 2, 3 and 1 (each within the scatter of the next).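

In this assay the steps to propylamino, the only open chain on the thiocarbonyl carbon in this set, are a 1.9-fold lower number from compound 3 to compound 4 (0.27 log units; within the scatter) and a 1.6-fold lower number from compound 2 to compound 4 (0.21 log units; within the scatter) and a 1.9-fold lower number from compound 1 to compound 4 (0.28 log units; within the scatter) so compound 4 cannot be told apart from any of the three ring compounds. The earlier steps shown here only exchanged one ring for another, whereas this change shows that the number stays within the scatter even when the ring is lost and a group with no hydrogen-bond donor gives way to one that has a hydrogen-bond donor. No measurement is available that would explain the size of these steps.

From the compounds shown here alone, this single chain says little about open chains in general, so it remains open whether a longer chain such as hexylamino, a branched one such as isopropylamino, or a phenylamino group would also stay within the scatter. Going by these compounds, it is equally open whether any group at this position can move the number beyond the scatter at all, since every comparison so far falls inside it.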